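Dimethylphenyl on the Ring Nitrogen: An Expected Read-out

The source may hold more compounds than are shown below. What is called first, only, known or untested is meant among the compounds shown, and "the series" means these compounds.

Compound 1 `COC(=O)C1=C(C)N(c2ccccc2)C=CC1c1ccccc1` and compound 2 `COC(=O)C1=C(C)N(c2ccccc2)C=C(C)C1c1ccccc1` were both tested in a functional assay, tested at 200 ug/mL; on this read-out lower numbers stand for a stronger effect and higher numbers for a weaker effect at the one concentration tested. In this assay compound 1 gives -23%, while compound 2 gives -33.1%. Within the data shown here, the one measured step, a number 10.1 percentage points lower from compound 1 to compound 2 (beyond the scatter), leaves compound 2 with the lowest of the two numbers, compound 1 being the nearest and standing higher by that step. Compound 3 `COC(=O)C1=C(C)N(c2cccc(C)c2C)C=C(C)C1c1ccccc1` differs from compound 2 by 2,3-dimethylphenyl in place of phenyl on an amine nitrogen in a ring. Among the measured compounds shown here, that step on the ring nitrogen is not covered by any measured pair: the only known step concerns a methyl on a double-bonded ring carbon and says nothing about the aryl group. With no guide from the data, the expectation for compound 3 is a step of about a number 1.9 percentage points lower from compound 2 to compound 3 (within the scatter) in this assay, not beyond the scatter. Compound 3 is therefore estimated at -35%, expected between -60% and -10%.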

Compound 3, a percentage reported as activity, at one concentration (the size of the read-out at that concentration, not a potency): -29.3%
Compound 3: middle estimate off by 5.7 percentage points, on the low side; measured number inside the range.
By their numbers in this assay, from the lowest: compounds 2, 3 and 1 (each within the scatter of the next, the first and the last beyond it).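

Among these compounds, the ring nitrogen had not been varied in the earlier compounds, and compound 3 gives the first reading at this place in this assay. With 2,3-dimethylphenyl in place of phenyl the result is a number 3.8 percentage points higher from compound 2 to compound 3 (within the scatter), so compound 2 and compound 3 cannot be told apart on this read-out. The aryl group on the ring nitrogen can therefore carry these two added methyl groups without a difference beyond the scatter, and nothing at hand offers an explanation for this result.

The compounds shown leave open whether a single methyl on the phenyl ring would read the same, and whether a different group on the ring nitrogen, such as benzyl or a phenyl ring bearing a carboxylic acid, would stay level too. Also open, as far as these compounds go, is whether the step on the double-bonded ring carbon, a number 10.1 percentage points lower from compound 1 to compound 2 (beyond the scatter), would recur with 2,3-dimethylphenyl on the nitrogen.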